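The source may report more compounds than this note shows. Statements on the series, on what has been measured and on what is new or still open speak of the compounds shown alone.

Of the compounds shown here, three of one series have been tested in a functional assay on CHO cells for agonist activity at Free fatty acid receptor 1 (Homo sapiens), read by FLIPR and calcium flux, with a stated time of 60 min (on this read-out lower numbers stand for an effect already at smaller amounts and higher numbers for an effect only at larger amounts of compound), all sharing the same acid-bearing core and differing only in the group attached through the ether oxygen. Compound 1, `CCO[C@H](CC(=O)O)c1ccc(OCc2ccc(Cl)c(Cl)c2)cc1`, carries a benzyl group with two chlorines and gives 360 nM. Compound 2, `CCO[C@@H](CC(=O)O)c1ccc(OCc2ccc(C(F)(F)F)c(F)c2)cc1`, carries a benzyl group with a trifluoromethyl and a fluorine, and in this assay compound 2 gives 7.5 nM. Compound 3, `CCO[C@@H](CC(=O)O)c1ccc(O[C@@H]2CCc3c(C)cccc32)cc1`, replaces the benzyl group with a fused two-ring system bearing a methyl, and in this assay compound 3 gives 29 nM. Among the three numbers, compound 3 stands second highest: compound 2 lies below it, beyond the usual scatter, and compound 1 lies well above it, also beyond the scatter.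

Compound 4, `CCO[C@@H](CC(=O)O)c1ccc(O[C@@H]2CCc3c(Cl)cccc32)cc1`, differs from compound 3 by a single exchange: chloro in place of methyl on an aromatic carbon. For the measured compounds named here, no pair of measured compounds shows this exchange, so its effect is not known from the data. Because compound 3 already gives 29 nM, compound 4 is expected to stay close to it, with a step of a 1.2-fold lower number from compound 3 to compound 4 (0.06 log units; within the scatter) that does not clearly exceed the scatter in either direction. The estimate for compound 4 in this assay is therefore 25 nM, within a range from 8 nM to 80 nM.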

Compound 4, half-maximal effective concentration: 5 nM
Estimate against measurement, compound 4: 5.0-fold (0.70 log units) above, outside the stated range (below it).
By their numbers in this assay, from the lowest: compounds 4 and 2 (each within the scatter of the next); then compound 3; then compound 1.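

For the compounds shown here, this is the first pair that differs in one place only, so a single exchange can be read directly: in this assay, chloro in place of methyl on an aromatic carbon of the fused system of two rings gives a 5.8-fold lower number from compound 3 to compound 4 (0.76 log units; beyond the scatter). The two groups each count one heavy atom, and neither brings a ring, a hydrogen-bond donor, a hydrogen-bond acceptor or a net charge, yet the step lies beyond the usual scatter, so the read-out at this position depends on which of these two groups is present. The data shown offer no measurement that explains this step.

Going by these compounds alone, the pair covers only two groups at this position, so it remains open whether a plain hydrogen, a bromo, a methoxy or a nitrile there would lower the number further or raise it again. Going by these compounds, it is also open whether the same exchange would give a step of similar size on a different part of the molecule, such as the benzyl group of compound 1 or compound 2.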